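This account rests on a few compounds, and the source may have more. Where it says the series, first, only, none or still open, it means among the compounds named here.

Compound 1 `COc1ccc(Cc2ccc3c(c2)/C(=C\c2cccc(OCc4cn(Cc5ccccc5)nn4)c2)C(=O)N3)cc1`: "not determined" (no result reported)
Compound 2 `Cc1ccc(C(C#Cc2ccccc2)c2ccc3c(c2)/C(=C/c2cccc(OCc4cn(Cc5ccccc5)nn4)c2)C(=O)N3)cc1`: > 50000 nM

Both compounds were examined in a functional assay on HeLa cells (Homo sapiens) for inhibition, read by MTT assay, with a stated time of 48 h; a higher number here means a weaker inhibitor, a lower number a stronger inhibitor. For compound 1 the entry is "not determined" (no result reported), so no number stands beside it. For compound 2 the result is a limit of the assay, > 50000 nM, and not a measured number. Going by the values given here, that is where compound 2 stands: one of the two entries is a limit (the limit of > 50000 nM in this assay, at which 1 of the 2 values shown sits) and the other carries no number at all, so no single figure anchors the pair, and no step between two measured compounds can be drawn.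

Compound 3 `Cc1ccc(C(C#Cc2ccccc2)c2ccc3c(c2)/C(=C\c2cccc(OCc4cn(Cc5ccccc5)nn4)c2)C(=O)N3)cc1` keeps every atom and bond of compound 2: the two compounds have the same atoms and bonds; at least one stereo element is drawn with a configuration in one of them and without one in the other: 1 of 2 stereo elements differ; a double bond is drawn Z in compound 2 and E in compound 3. Among the compounds with values here, the only change is the geometry of that double bond, drawn Z in compound 2 and E in compound 3. With compound 2 sitting at the limit, a sharper inhibition by compound 3 would have to be large to register as a number. The step in this assay is expected to be none beyond the scatter, namely a number no higher from compound 2 to compound 3 (the limit leaves the size open). Compound 3 is therefore estimated to come out near 50000 nM, between 15000 nM and 100000 nM, with a real chance that only a limit is reported again.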

Compound 3, half-maximal inhibitory concentration: 32800 nM
Estimate against measurement, compound 3: 1.5-fold (0.18 log units) above; low and high end bracket the measured number.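

In this assay compound 3 supplies the first actual number among these compounds, 32800 nM, so the geometry of the double bond can now be tied to a reading and not only to an entry without a figure. For compound 2 the entry > 50000 nM is a limit of the assay and not a number. The geometry change gives an at least 1.5-fold lower number from compound 2 to compound 3 (0.18 log units; that floor lies within the scatter), so the true size of the step could be small or large, and the pair is a clean comparison in that only this one place differs: the fact that one of compounds 2 and 3 is drawn with a defined configuration and the other without, at the place where they differ

The compounds shown leave open how large the effect of the double bond geometry really is, since a firm number on the Z side would be needed to settle it. They also leave open whether the reading in this assay would move if the methyl group on the outer benzene ring gave way to an amine or a carboxylic acid, and whether the geometry would then count in the same way.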